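A few compounds are considered here, and "the series" means these few. Any claim that something is new, unique, unknown or untested is made for them only; others in the source may bear on it.

Measured compounds in a functional assay on NCI-H1299 cells (Homo sapiens) for antiproliferative activity, with a stated time of 72 h; a lower number here means that less compound is needed, a higher number that more compound is needed for the effect:
compound 1, `CN1CCN(c2ccc(Nc3ncc4c(=O)c(-c5c(Cl)cccc5Cl)cn(C)c4n3)cc2)CC1`, 520 nM
compound 2, `CN1CCN(c2ccc(Nc3ncc4c(=O)c(-c5c(Cl)cccc5Cl)cn(C5CC5)c4n3)cc2)CC1`, 460 nM

Compound 2 carries the lowest of the two numbers in this assay; its nearest neighbour is compound 1, and the gap between them is within the scatter, so the two cannot be ranked. Compound 3, `CN1CCN(c2ccc(Nc3ncc4c(=O)c(-c5c(Cl)cccc5Cl)cn(C5COC5)c4n3)cc2)CC1`, differs from compound 2 in one place: oxetan-3-yl in place of cyclopropyl on an aromatic nitrogen. Within the data shown here, the only measured step that bears on this position, a 1.1-fold lower number from compound 1 to compound 2 (0.05 log units; within the scatter), also exchanged the group on that aromatic nitrogen and left the number within the scatter. Since nothing in the measured pair shows that this position moves the number, no step beyond the scatter is expected in this assay for the further exchange, and no direction can be given. Compound 3 is therefore estimated to give 550 nM in this assay, with a range from 250 nM to 1200 nM. The expected step is a 1.2-fold higher number from compound 2 to compound 3 (0.08 log units; within the scatter).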

Compound 3, half-maximal effective concentration: 1720 nM
For compound 3 the middle estimate is 3.1-fold (0.50 log units) below the measured one; measured number outside the range, above it.
By their numbers in this assay, from the lowest: compounds 2 and 1 (each within the scatter of the next); then compound 3.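

In this assay this position turns out not to be indifferent to its substituent: where methyl and cyclopropyl could not be told apart, oxetan-3-yl gives a 3.7-fold higher number from compound 2 to compound 3 (0.57 log units; beyond the scatter) and, set against methyl, a 3.3-fold higher number from compound 1 to compound 3 (0.52 log units; beyond the scatter) as well. The exchange for cyclopropyl enlarges the three-membered ring of carbon only to a four-membered ring with one oxygen, and it is this group that stands apart from the two smaller ones. Nothing available accounts for the step.

The compounds shown leave open whether the ring size or the ring oxygen carries the step, a question on which cyclobutyl on the same nitrogen would bear. They also leave open how a longer chain or a ring carrying an amine would behave at this position.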